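The compounds below may be only part of what the source reports. "The series", "measured", "known", "first", "only" and "open" are said of these compounds alone.

Compound 1 `CC(C)n1ncc2c(C(=O)NCc3cn(-c4ccccc4)nn3)cccc21` is the reference point of this small series: in a functional assay on PC-3 cells (Homo sapiens) for inhibition, read by MTT assay, with a stated time of 72 h (on this read-out lower numbers stand for stronger inhibition and higher numbers for weaker inhibition), compound 1 gives 26000 nM. Compound 2 `CC(C)n1ncc2c(C(=O)NCc3cn(-c4ccccc4F)nn3)cccc21` carries a fluoro in place of a hydrogen on an aromatic carbon. In this assay compound 2 reaches only a limit, > 40000 nM, and no number. Among the compounds with values here, the resulting step of an at least 1.5-fold higher number from compound 1 to compound 2 (0.18 log units; that floor lies within the scatter) is the only measured step in the set, and it rests on the limit of > 40000 nM in this assay, at which 1 of the 2 values shown sits, rather than on a full value. Compound 3 `COc1ccc(-n2cc(CNC(=O)c3cccc4c3cnn4C(C)C)nn2)cc1` differs from compound 2 by 4-methoxyphenyl in place of 2-fluorophenyl on an aromatic nitrogen. Within the data shown here, no measured step bears directly on this exchange; the single measured step, from compound 1 to compound 2, concerns a different substituent and has a floor within the scatter, so it gives no indication of direction beyond the scatter for this assay. Compound 3 is therefore expected to sit near where compound 2 stands, with an expected step of a number no higher from compound 2 to compound 3 (the limit leaves the size open). On that basis compound 3 is estimated at 40000 nM, in a range from 15000 nM to 120000 nM, with a real chance that this assay again reports only a limit.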

Compound 3, half-maximal inhibitory concentration: 34300 nM
The estimate for compound 3 lay 1.2-fold (0.07 log units) above the measured number; the measured number falls inside the stated range.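

With 4-methoxyphenyl on the aromatic nitrogen of the five-membered ring, this assay returns a full value, so a substituted phenyl group at this position can now be compared with the plain phenyl of compound 1 on actual numbers rather than on a limit. That comparison gives a 1.3-fold higher number from compound 1 to compound 3 (0.12 log units; within the scatter), so adding this methoxy to the phenyl group produces no difference that can be told from the scatter. The other step, an at least 1.1-fold lower number from compound 2 to compound 3 (0.06 log units; that floor lies within the scatter), gives only a floor, and its true size stays open because it rests on a limit: the limit of > 40000 nM in this assay, at which 1 of the 3 values shown sits.

The compounds shown leave open whether any group on this phenyl ring can move the number beyond the scatter from compound 1, for instance an amine or a carboxylic acid in the place of the methoxy. They also leave open whether the outcome depends on where the substituent sits, since 2-fluorophenyl and 4-methoxyphenyl differ in both the group and its place, and a 2-methoxyphenyl or 4-fluorophenyl would be needed to separate the two.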